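The compounds below may be only part of what the source reports. "The series", "measured", "known", "first", "only" and "open" are said of these compounds alone.

Working notes on the series, read in a functional assay on HeLa cells (Homo sapiens) for antiproliferative activity, read by CCK-8 assay, with a stated time of 72 h; on this read-out higher numbers stand for weaker inhibition and lower numbers for stronger inhibition. Compound 1 `COc1ccc(-c2cncnc2-c2cc(OC)c(OC)c(OC)c2)cc1O` gives 280 nM, compound 2 `COc1ccc(-c2cncnc2-c2cc(OC)c(OC)c(OC)c2)cc1Cl` gives 320 nM and compound 3 `COc1cc(-c2ncncc2-c2ccc(SC)cc2)cc(OC)c1OC` gives 220 nM. Compound 3 is not separated from the other two, since its gaps to them are a 1.3-fold lower number from compound 1 to compound 3 (0.10 log units; within the scatter) and a 1.5-fold lower number from compound 2 to compound 3 (0.16 log units; within the scatter). The remaining pair shows a 1.1-fold higher number from compound 1 to compound 2 (0.06 log units; within the scatter), so the three values form one level in this assay.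

Compound 4 `COc1ccc(-c2cncnc2-c2cc(OC)c(OC)c(OC)c2)nc1` has 5-methoxypyridin-2-yl in place of 4-(methylsulfanyl)phenyl on an aromatic carbon. The two steps that exchange the aryl group at this same place, those ending at compound 3, are the ones that bear on it, and both stayed small. They suggest tolerance for change here, but they cover only rings of carbon. Among the compounds with values here, no measured compound has a ring with a hetero atom at this place, so the data leave that part of the change untested. A modest move toward a higher number, meaning weaker inhibition, is therefore expected rather than a large one, and no change beyond the scatter remains possible. The expected size is a 2.3-fold higher number from compound 3 to compound 4 (0.36 log units; beyond the scatter). For compound 4 the estimated value is 500 nM, with an expected range of 170 nM to 1800 nM.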

Compound 4, half-maximal inhibitory concentration: 470 nM
For compound 4 the middle estimate is 1.1-fold (0.03 log units) above the measured one, within the range that was stated.
By their numbers in this assay, from the lowest: compounds 3, 1, 2 and 4 (each within the scatter of the next, the first and the last beyond it).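

Within the data shown here, with 5-methoxypyridin-2-yl, a ring with a hetero atom enters this place for the first time, and in this assay the exchange gives a 2.1-fold higher number from compound 3 to compound 4 (0.33 log units; beyond the scatter) as the first step at this place to leave the scatter. Against the other two aryl groups, the same entering ring gives a 1.5-fold higher number from compound 2 to compound 4 (0.17 log units; within the scatter) and a 1.7-fold higher number from compound 1 to compound 4 (0.22 log units; within the scatter) and so is separated from 4-(methylsulfanyl)phenyl alone, not from 3-chloro-4-methoxyphenyl or 3-hydroxy-4-methoxyphenyl. The tolerance at this place therefore extends to a ring with a hetero atom, with only a modest step against one of the three earlier groups, and nothing measured gives a reason for that step.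

The step from compound 3 to compound 4 exchanges the ring nitrogen and the substituent together, so a methoxyphenyl ring of carbon only would be needed to tell their shares apart. How this place responds to an amine or a carboxylic acid on the aryl ring, or to a longer alkoxy chain in place of the methoxy, remains open in the compounds shown.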